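The compounds below may be only part of what the source reports. "The series", "measured", "known", "first", "only" and "open" are said of these compounds alone.

Compound 3 `COc1cc(Cl)cc(-c2nn(-c3cccc(NC(=O)Nc4cc(C(F)(F)F)cc(C(F)(F)F)c4)c3)cc2-c2ccncc2)c1` gives -81% in a functional assay on OVCAR-3 cells (Homo sapiens) for inhibition, read by sulforhodamine B assay, with a stated time of 48 h, tested at 100 uM (on this read-out higher numbers stand for a weaker effect at the one concentration tested and lower numbers for a stronger effect), the lowest of the three numbers measured. For the measured compounds named here, compound 2 `COc1cc(Cl)cc(-c2nn(-c3cccc(NC(=O)Nc4ccc(Cl)c(C(F)(F)F)c4)c3)cc2-c2ccncc2)c1` gives -56% and compound 1 `O=C(Nc1cccc(-n2cc(-c3ccncc3)c(-c3cc(O)cc(Cl)c3)n2)c1)Nc1ccc(Cl)c(C(F)(F)F)c1` gives -1%; the only single change measured, a number 55 percentage points lower from compound 1 to compound 2 (beyond the scatter), bears on a different part of the molecule. Compound 4 `COc1cc(Cl)cc(-c2nn(-c3cccc(NC(=O)Nc4cccc(C(F)(F)F)c4)c3)cc2-c2ccncc2)c1` differs from compound 3 by hydrogen in place of trifluoromethyl on an aromatic carbon. Going by the values given here, no measured step covers this change, so the expectation rests only on the spread seen among compounds 1 to 3. Compound 4 is expected to show a weaker effect than compound 3, with an estimated step of a number 36 percentage points higher from compound 3 to compound 4 (beyond the scatter). The estimate for compound 4 is therefore -45%, within a range from -80% to -5%.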

Compound 4, a percentage reported as activity, at one concentration (the size of the read-out at that concentration, not a potency): -41%
For compound 4 the middle estimate is 4 percentage points below the measured one, and the stated range covers the measured number.
By their numbers in this assay, from the lowest: compound 3; then compound 2; then compound 4; then compound 1.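

In this assay, hydrogen in place of trifluoromethyl on this aromatic carbon is a large loss of effect (a number 40 percentage points higher from compound 3 to compound 4 (beyond the scatter)), so the read-out depends on what this carbon carries. Hydrogen in place of chloro on the same ring is a modest loss (a number 15 percentage points higher from compound 2 to compound 4 (beyond the scatter)), so a second halogen-bearing substituent on this ring also counts. Nothing measured here explains either step. Still open, on these data alone, is whether a smaller fluoro or methyl group on this carbon would retain the effect, and how an amine or a carboxylic acid there would read.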